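This account rests on a few compounds, and the source may have more. Where it says the series, first, only, none or still open, it means among the compounds named here.

Measured in a functional assay on T47D cells (Homo sapiens) for cytotoxicity, read by MTT assay, with a stated time of 3 h; a higher number here means a weaker inhibitor, a lower number a stronger inhibitor:
- compound 1 `O=c1cc(N2CCNCC2)c2cc(F)ccc2[nH]1`: 37700 nM
- compound 2 `COc1ccc(-c2csc(NC(=O)CN3CCN(c4cc(=O)[nH]c5ccc(F)cc45)CC3)n2)cc1`: 16900 nM
- compound 3 `O=C(CN1CCN(c2cc(=O)n(-c3ccccc3)c3ccccc23)CC1)Nc1nc(-c2ccc(Cl)cc2)cs1`: 30200 nM

The three compounds form a small set, and no two of them differ in only one place. Compound 3, at 30200 nM, lies within the usual scatter of both compound 1 and compound 2, so its number cannot be separated from either neighbour.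

The next compound to be tested is compound 4 `O=C(CN1CCN(c2cc(=O)n(-c3ccccc3)c3ccccc23)CC1)Nc1nc(-c2ccccc2)cs1`. It keeps the whole of compound 3 except for one substituent: hydrogen in place of chloro on an aromatic carbon, para to a large group, so that 4-chlorophenyl becomes phenyl. The counted difference is hydrogen in place of chloro on an aromatic carbon.

Among the compounds with values here, no measured pair in this set shows what this exchange does in this assay, so there is no direct precedent for its size or direction. The best available anchor is compound 3 itself, at 30200 nM. With nothing to point either way, no change beyond the scatter is expected. The estimated 1.0-fold lower number from compound 3 to compound 4 (0.00 log units; within the scatter) is accordingly small and has no firm direction. For compound 4 the expected value is 30000 nM, with an estimated range of 13000 nM to 70000 nM.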

Compound 4, half-maximal inhibitory concentration: 10300 nM
Beside the measured number, compound 4's estimate is 2.9-fold (0.46 log units) above it; the measured number lies below the stated range.
By their numbers in this assay, from the lowest: compounds 4, 2, 3 and 1 (each within the scatter of the next, the first and the last beyond it).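

Within the data shown here, exchanging chloro for hydrogen on the aromatic carbon para to a large group, so that 4-chlorophenyl becomes phenyl, gives the first readable step in this assay, namely a 2.9-fold lower number from compound 3 to compound 4 (0.47 log units; beyond the scatter), a change rated modest. It shows that this position is not indifferent in this assay: the loss of one heavy atom, with no hydrogen-bond donor, hydrogen-bond acceptor or net charge involved, is enough to move the number beyond the scatter, and the direction favours the unsubstituted phenyl. Nothing available explains why this exchange has this effect.

The compounds shown leave open whether the lower number belongs to hydrogen in particular or whether other groups at this position, such as bromo, methyl or an amine, would also differ from chloro, since a single pair gives only one direction and one size. Among these compounds, they also leave open whether the same exchange would have a similar effect on the core of compound 2, as this step has been seen only on the core shared by compound 3 and compound 4.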